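This account rests on a few compounds, and the source may have more. Where it says the series, first, only, none or still open, it means among the compounds named here.

Compound 2 `COc1ccc(-c2sc(N)c(C(=O)c3ccc(Cl)cc3)c2C)cc1` was tested in an assay on CHO cells for displacement of a labelled ligand from adenosine receptor A1 (Homo sapiens), read by scintillation counting, tested at 10 uM (a higher number here means more inhibition at the concentration tested (going by the name of the read-out), a lower number less inhibition), where compound 2 gives 1%. Its closest measured neighbour is compound 1 `Cc1csc(N)c1C(=O)c1ccc(Cl)cc1`, which in this assay gives 1%. For the measured compounds named here, the only measured step, no change at the digits printed from compound 1 to compound 2 (within the scatter), shows that adding a 4-methoxyphenyl group on an aromatic carbon of the shared core left the read-out essentially where it was, so compound 2 stands level with compound 1 within the scatter.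

Compound 3 `Cc1c(Br)sc(N)c1C(=O)c1ccc(Cl)cc1` differs from compound 2 in one place: bromo in place of 4-methoxyphenyl on an aromatic carbon. Going by the values given here, no measured step covers a bromo group at this position, so the expectation rests only on the fact that both measured compounds sit near the bottom of the scale. Compound 3 is therefore expected to show a step of a number 2 percentage points higher from compound 2 to compound 3 (within the scatter), meaning no change beyond the scatter. The estimate for compound 3 in this assay is 3%, with a range from 0% to 15%.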

Compound 3, a percentage reported as inhibition, at one concentration (the size of the read-out at that concentration, not a potency): 1%
Beside the measured number, compound 3's estimate is 2 percentage points above it; low and high end bracket the measured number.
By their numbers in this assay, from the lowest: compounds 1, 2 and 3 (each within the scatter of the next).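

With a bromo group now also on the aromatic carbon next to the ring sulfur, this assay gives no change at the digits printed from compound 2 to compound 3 (within the scatter) and no change at the digits printed from compound 1 to compound 3 (within the scatter) as its two new steps. This position has now carried hydrogen, a single bromine atom and the ring-bearing 4-methoxyphenyl group, and the three compounds cannot be told apart, so neither the presence of a group here nor its size separates them in this read-out. Nothing measured here bears on the reason for this result.

From the compounds shown here alone, all three values lie near the bottom of the scale, so it remains open whether any group at this position can raise the inhibition at all. An amine, a carboxylic acid or a longer chain such as butyl on this carbon would test that.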